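From fluoro to trifluoromethyl on compound 2

The compounds below may be only part of what the source reports. "The series", "measured", "known", "first", "only" and "open" are said of these compounds alone.

Of the compounds shown here, two have been measured so far. In an ADME assay on Vero cells (Chlorocebus sabaeus) for cytotoxicity, read by resazurin assay, with a stated time of 72 h (on this read-out lower numbers stand for stronger inhibition and higher numbers for weaker inhibition), compound 2 (`Cc1ccc(C(=O)CCN2CCN(c3ccc(F)cc3)CC2)cc1`) gives 55400 nM, the higher of the two numbers. Compound 1 (`O=C(CCN1CCN(c2ccc(C(F)(F)F)cc2)CC1)c1ccccc1`) gives 15700 nM, and the gap between the two lies beyond the scatter. Compound 3 (`Cc1ccc(C(=O)CCN2CCN(c3ccc(C(F)(F)F)cc3)CC2)cc1`) is compound 2 with trifluoromethyl in place of fluoro on an aromatic carbon, para to a large group: trifluoromethyl in place of fluoro on an aromatic carbon. Going by the values given here, no measured pair isolates this change, so the expectation rests on a single comparison. Compound 1 also carries trifluoromethyl and gives 15700 nM, although it differs from compound 2 in a second place as well. A step toward a lower number in this assay, beyond the scatter, is therefore expected: a 2.9-fold lower number from compound 2 to compound 3 (0.46 log units; beyond the scatter). For compound 3 the estimated value is 19000 nM, with an expected range of 8000 nM to 45000 nM.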

Compound 3, half-maximal inhibitory concentration: 140000 nM
For compound 3 the middle estimate is 7.4-fold (0.87 log units) below the measured one; the whole stated range lies below it.
By their numbers in this assay, from the lowest: compound 1; then compound 2; then compound 3.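

In this assay trifluoromethyl in place of fluoro on an aromatic carbon, para to a large group, gives a 2.5-fold higher number from compound 2 to compound 3 (0.40 log units; beyond the scatter) and shows that this change can raise the number at this position when the methyl is present. Methyl in place of hydrogen on an aromatic carbon gives an 8.9-fold higher number from compound 1 to compound 3 (0.95 log units; beyond the scatter) with trifluoromethyl held constant, so the low number of compound 1 is tied to the missing methyl rather than to trifluoromethyl alone. No measurement shown here accounts for either step.

The compounds shown leave open whether the methyl step would have a similar size with fluoro in place of trifluoromethyl. They also leave open where chloro, methoxy or nitrile at this same position would fall relative to fluoro and trifluoromethyl.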